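The compounds below may be only part of what the source reports. "The series", "measured", "known", "first", "only" and "open" are said of these compounds alone.

The series shares one core and is varied on the anilino ring. Compound 1 `N#Cc1c(Nc2cccc(C(F)(F)F)c2)nc(SCc2cn(Cc3ccccc3Cl)nn2)nc1-c1ccccc1` carries a trifluoromethyl there and in a functional assay on B16-F10 cells (Mus musculus) for inhibition, read by MTT assay, with a stated time of 72 h (on this read-out lower numbers stand for stronger inhibition and higher numbers for weaker inhibition), compound 1 gives 3710 nM. Compound 2 `N#Cc1c(Nc2cccc([N+](=O)[O-])c2)nc(SCc2cn(Cc3ccccc3Cl)nn2)nc1-c1ccccc1` carries a nitro instead; in this assay compound 2 gives 17200 nM. Compound 3 `N#Cc1c(Nc2ccccc2)nc(SCc2cn(Cc3ccccc3Cl)nn2)nc1-c1ccccc1` has the unsubstituted ring, and in this assay compound 3 gives 28300 nM, the highest of the three numbers. The step of a 7.6-fold higher number from compound 1 to compound 3 (0.88 log units; beyond the scatter) lies beyond the scatter, as does a 4.6-fold higher number from compound 1 to compound 2 (0.67 log units; beyond the scatter), whereas a 1.6-fold higher number from compound 2 to compound 3 (0.22 log units; within the scatter) stays within it.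

Compound 4 `Cc1ccc(Nc2nc(SCc3cn(Cc4ccccc4Cl)nn3)nc(-c3ccccc3)c2C#N)cc1` is not yet measured. The change from compound 3 to compound 4 is methyl in place of hydrogen on an aromatic carbon. Going by the values given here, no measured step introduces a methyl anywhere, so the two measured substituent steps bear on it only loosely: removing trifluoromethyl cost clearly, removing nitro did not register beyond the scatter. A methyl is expected to give at most a small change in this assay, if anything toward a lower number; the estimated step is a 1.8-fold lower number from compound 3 to compound 4 (0.25 log units; within the scatter). For compound 4 the estimate in this assay is 16000 nM, with a range from 5000 nM to 50000 nM.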

Compound 4, half-maximal inhibitory concentration: 3390 nM
Beside the measured number, compound 4's estimate is 4.7-fold (0.67 log units) above it; the whole stated range lies above it.
By their numbers in this assay, from the lowest: compounds 4 and 1 (each within the scatter of the next); then compounds 2 and 3 (each within the scatter of the next).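

In this assay, a single methyl para to a large group is enough to move the unsubstituted ring: an 8.3-fold lower number from compound 3 to compound 4 (0.92 log units; beyond the scatter), so a step beyond the scatter at this ring does not depend on trifluoromethyl or nitro. The new group also separates from nitro, with a 5.1-fold lower number from compound 2 to compound 4 (0.71 log units; beyond the scatter), while a 1.1-fold lower number from compound 1 to compound 4 (0.04 log units; within the scatter) leaves 4-methylphenyl and 3-(trifluoromethyl)phenyl indistinguishable here, even though these two rings differ in both the group and its place. No measurement available here accounts for the effect of the methyl, and its origin stays unassigned.

No group among the compounds shown appears at both places on the ring, so the contribution of the group and that of its place remain inseparable, and 3-methylphenyl and 4-(trifluoromethyl)phenyl would be the direct tests. From the compounds shown here alone, it also remains open whether the step from compound 3 to compound 4 persists with a longer chain such as ethyl, or with a methoxy or an amine, at the place the methyl occupies.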